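From 4-nitrophenyl to 2,4-dimethylphenyl on the shared core

The compounds below may be only part of what the source reports. "The series", "measured", "known", "first", "only" and "open" are said of these compounds alone.

In a functional assay on A549 cells (Homo sapiens) for inhibition, read by MTT assay, with a stated time of 72 h (on this read-out lower numbers stand for stronger inhibition and higher numbers for weaker inhibition), compound 1 (`Cc1cc2occ(-c3nc(-c4ccccc4)c(-c4ccccc4)n3-c3ccc([N+](=O)[O-])cc3)c(=O)c2cc1Cl`) gives 3130 nM and sits at the low end of the three measured values, though not apart from compound 2 (`Cc1cc2occ(-c3nc(-c4ccccc4)c(-c4ccccc4)n3-c3ccc(Cl)c(Cl)c3)c(=O)c2cc1Cl`), which gives 6250 nM and stays within the scatter of it. Compound 3 (`Cc1cccc(-n2c(-c3coc4cc(C)c(Cl)cc4c3=O)nc(-c3ccccc3)c2-c2ccccc2)c1`) gives 12500 nM and stands clear of compound 1. Compound 4 (`Cc1ccc(-n2c(-c3coc4cc(C)c(Cl)cc4c3=O)nc(-c3ccccc3)c2-c2ccccc2)c(C)c1`) has not yet been measured and differs from compound 1 in one place (2,4-dimethylphenyl in place of 4-nitrophenyl on an aromatic nitrogen), with 2,4-dimethylphenyl in place of 4-nitrophenyl on an aromatic nitrogen. The closest guide is the move to 3-methylphenyl on that nitrogen (a 4.0-fold higher number from compound 1 to compound 3 (0.60 log units; beyond the scatter)). The move to 3,4-dichlorophenyl (a 2.0-fold higher number from compound 1 to compound 2 (0.30 log units; within the scatter)) and the change from that group to 3-methylphenyl (a 2.0-fold higher number from compound 2 to compound 3 (0.30 log units; within the scatter)) are smaller. Among the compounds with values here, no measured compound carries 2,4-dimethylphenyl, so the guide is only partial. A modest step towards a higher number in this assay is therefore expected (a 4.0-fold higher number from compound 1 to compound 4 (0.60 log units; beyond the scatter)). The estimate for compound 4 is 12500 nM (expected range 5000 nM to 30000 nM).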

Compound 4, half-maximal inhibitory concentration: 6250 nM
Estimate against measurement, compound 4: 2.0-fold (0.30 log units) above; the measured number falls inside the stated range.
By their numbers in this assay, from the lowest: compounds 1, 2, 4 and 3 (each within the scatter of the next, the first and the last beyond it).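

In this assay, replacing 4-nitrophenyl with 2,4-dimethylphenyl removes the nitrogen and oxygen atoms of the departing group, yet the step stays within the scatter (a 2.0-fold higher number from compound 1 to compound 4 (0.30 log units; within the scatter)), so a substituent of carbon only on this aromatic nitrogen need not move the number beyond it, although compound 3 goes against this (a 4.0-fold higher number from compound 1 to compound 3 (0.60 log units; beyond the scatter)). Compound 4 is also not separated from its neighbours carrying other substituted phenyl groups (a 2.0-fold lower number from compound 3 to compound 4 (0.30 log units; within the scatter); no change at the digits printed from compound 2 to compound 4 (within the scatter)). Nothing available explains these numbers.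

Going by these compounds, all four compounds carry a substituted phenyl group on this nitrogen, so the effect of an unsubstituted phenyl, a longer alkyl chain or a group bearing an amine or a carboxylic acid remains open. On these data alone, the two phenyl groups on the neighbouring ring atoms also stay unchanged throughout, so what this read-out would do if they were altered is equally open.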